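Moving the chlorine on the sulfonyl ring

The source may report more compounds than this note shows. Statements on the series, on what has been measured and on what is new or still open speak of the compounds shown alone.

Going by the values given here, compound 2 `O=C(/C=C/c1cccc(NS(=O)(=O)c2cccc(Cl)c2)c1)c1nc2ccccc2[nH]1` is one of two compounds measured in a functional assay on 143B cells (Homo sapiens) for antiproliferative activity, read by MTT assay, with a stated time of 48 h; a lower number here means a stronger inhibitor, a higher number a weaker inhibitor. In this assay compound 2 gives 2510 nM, the lower of the two numbers. Among the compounds with values here, its only measured neighbour is compound 1 `O=C(Nc1cccc(/C=C/C(=O)c2nc3ccccc3[nH]2)c1)c1ccccc1`, which in this assay gives 8340 nM; the step of a 3.3-fold lower number from compound 1 to compound 2 (0.52 log units; beyond the scatter) is the single measured step available, and it concerns the exchange of benzoyl for (3-chlorophenyl)sulfonyl on a nitrogen on an aromatic ring.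

Compound 3 `O=C(/C=C/c1cccc(NS(=O)(=O)c2ccc(Cl)cc2)c1)c1nc2ccccc2[nH]1` has not yet been measured. It differs from compound 2 only in where the chlorine sits: 4-chlorophenyl in place of 3-chlorophenyl on a sulfonyl sulfur. Within the data shown here, no measured step shows how this assay responds to such a shift; the one step from compound 1 to compound 2 swaps the whole group and so does not bear on it directly. With no guidance of that kind, the expectation is a step of no particular direction, a 1.0-fold lower number from compound 2 to compound 3 (0.00 log units; within the scatter), staying within the scatter. Compound 3 is therefore estimated at 2500 nM in this assay, with a range from 900 nM to 7000 nM.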

Compound 3, half-maximal inhibitory concentration: 7450 nM
Estimate against measurement, compound 3: 3.0-fold (0.47 log units) below, and the stated range ends below it.
By their numbers in this assay, from the lowest: compound 2; then compounds 3 and 1 (each within the scatter of the next).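

In this assay, the two compounds have the same atoms joined differently, and moving the chlorine gives a 3.0-fold higher number from compound 2 to compound 3 (0.47 log units; beyond the scatter), so this position responds to where the chlorine sits on the ring and not only to which atoms are there. This also changes how the earlier exchange reads: a sulfonyl group in place of benzoyl does not by itself go with a lower number, since the (4-chlorophenyl)sulfonyl compound gives a 1.1-fold lower number from compound 1 to compound 3 (0.05 log units; within the scatter), and among these three compounds only compound 2, with its 3-chlorophenyl group, stands apart from compound 1. Nothing available here explains why the two chlorine placements differ.

The compounds shown leave open whether the lower number of compound 2 is tied to chlorine itself or would also appear with fluorine, methyl or methoxy in its place, and how a plain phenyl on the sulfonyl sulfur would compare with both chlorophenyl groups. They also leave open whether a chlorine on the benzoyl ring of compound 1 would show the same dependence on its place.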